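Swapping bromine for fluorine on a chalcone-type scaffold

A few compounds are considered here, and "the series" means these few. Any claim that something is new, unique, unknown or untested is made for them only; others in the source may bear on it.

Measured so far:
Compound 1, `COc1cc(O)c(C(=O)/C=C/c2ccc(F)cc2)c(OC)c1`: 37%
Compound 2, `COc1cccc(/C=C/C(=O)c2c(OC)cc(OC)cc2OC)c1`: 23%
Compound 3, `COc1cc(OC)c(C(=O)/C=C/c2ccc(Br)cc2)c(OC)c1`: 35%

All three were tested in a functional assay on PC-3 cells (Homo sapiens), read by fluorescence and BrdU incorporation, with a stated time of 48 h, tested at 10 uM; a lower number here means a stronger effect, a higher number a weaker effect of the compound at the concentration tested. Compound 3 stands second highest of the three numbers; its nearest neighbour is compound 1, whose value lies within the scatter of it, while compound 2 lies furthest away, its number being lower by more than the scatter.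

Compound 4, `COc1cc(OC)c(C(=O)/C=C/c2ccc(F)cc2)c(OC)c1`, has not yet been measured. It differs from compound 3 by one atom: fluoro in place of bromo on an aromatic carbon. Among the compounds with values here, the only measured step concerns a different change, a number 12 percentage points higher from compound 2 to compound 3 (beyond the scatter), where a 4-bromophenyl replaced a 3-methoxyphenyl; it does not bear on a halogen swap. Compound 1 already carries the 4-fluorophenyl group, but it differs from compound 3 in a second place as well, so its value and that of compound 3 only show two numbers that lie within the scatter of each other.

Within the data shown here, with no step touching the bromo-to-fluoro change itself, no shift beyond the scatter is expected, a number 1 percentage points higher from compound 3 to compound 4 (within the scatter). Compound 4 is therefore estimated at 36% in this assay, with a range from 22% to 50%.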

Compound 4, a percentage reported as activity, at one concentration (the size of the read-out at that concentration, not a potency): 27%
Compound 4: the middle estimate sits 9 percentage points above what was measured; low and high end bracket the measured number.
By their numbers in this assay, from the lowest: compounds 2, 4, 3 and 1 (each within the scatter of the next, the first and the last beyond it).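

In this assay the swap of bromo for fluoro, on an aromatic carbon para to a large group, gives a number 8 percentage points lower from compound 3 to compound 4 (within the scatter) and so, at this single concentration, the two halogens cannot be told apart on this core. Within the data shown here, the other new steps also stay within the usual scatter: adding methyl in place of hydrogen on the oxygen on the aromatic ring gives a number 10 percentage points lower from compound 1 to compound 4 (within the scatter) and putting 4-fluorophenyl in place of 3-methoxyphenyl gives a number 4 percentage points higher from compound 2 to compound 4 (within the scatter) while the matching change to 4-bromophenyl gave a number 12 percentage points higher from compound 2 to compound 3 (beyond the scatter) and was the only one of these steps beyond the scatter. No independent measurement is available to explain any of these numbers.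

Going by these compounds, only two halogens appear at this position, so it remains open whether a chloro, an amine or a carboxylic acid placed there would give a number clearly apart from those of compound 3 and compound 4. A single reading at one concentration on one cell line also leaves open how these compounds would compare across a range of concentrations.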